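The source may hold more compounds than are shown below. What is called first, only, known or untested is meant among the compounds shown, and "the series" means these compounds.

Measured so far in an ADME assay on CEM174 cells (Homo sapiens) for cytotoxicity; a higher number here means that more compound is tolerated, a lower number that less compound is tolerated:
compound 1 `Cc1ccccc1-c1cnnc(NCc2cc(-c3ccccc3)[nH]n2)n1` gives > 10000 nM
compound 2 `Cc1cccc(-c2cnnc(NCc3cc(-c4ccccc4)[nH]n3)n2)c1` gives > 10000 nM
compound 3 `Cc1ccc(-c2cnnc(NCc3cc(-c4ccccc4)[nH]n3)n2)cc1` gives > 10000 nM

Each of these three values is a limit of the assay, not a measured number, so compound 3 stands at the limit of > 10000 nM in this assay, at which 3 of the 3 values shown sit. The steps a step that the two limits leave unreadable from compound 1 to compound 2, a step that the two limits leave unreadable from compound 1 to compound 3 and a step that the two limits leave unreadable from compound 2 to compound 3 therefore cannot be sized; moving the methyl around the phenyl ring gave no readable change in tolerated concentration. Compound 4 `Cc1cc(C#N)ccc1-c1cnnc(NCc2cc(-c3ccccc3)[nH]n2)n1` carries a different change: 4-cyano-2-methylphenyl in place of 4-methylphenyl on an aromatic carbon. For the measured compounds named here, the measured steps say only that every variant so far was tolerated up to the limit, and a cyano group added to the same ring has no measured precedent here. The expected step that the limit leaves unreadable from compound 3 to compound 4 is thus one that likely cannot be read either. Compound 4 is estimated at 15000 nM, between 5000 nM and 50000 nM.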

Compound 4, half-maximal cytotoxic concentration: > 10000 nM
Compound 4 was reported as a limit; the forecaster's own chance of this, stated with the estimate: 75%; the middle value lies beyond the limit too.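

Compound 4 also gives only a limit in this assay, not a measured number, so its steps from compound 1, compound 2 and compound 3 cannot be read: the limit of > 10000 nM in this assay, at which 4 of the 4 values shown sit. What stays open is the concentration at which any of these compounds becomes toxic to the cells, and whether the cyano group changes it.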